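A butyl chain in place of the sulfonylphenoxy arm

The compounds below may be only part of what the source reports. "The series", "measured", "known", "first", "only" and "open" are said of these compounds alone.

Measured compounds:
Compound 1 `Cn1c(-c2ccccc2C(F)(F)F)nnc1C12CCC(CNS(C)(=O)=O)(CC1)CC2`: > 4000 nM
Compound 2 `Cn1c(-c2ccccc2C(F)(F)F)nnc1C12CCC(COc3ccc(S(C)(=O)=O)cc3)(CC1)CC2`: > 4000 nM

In an assay on CHO-K1 cells for inhibition of 11-beta-hydroxysteroid dehydrogenase type 2 (Homo sapiens), read by scintillation proximity assay (a lower number here means a stronger inhibitor, a higher number a weaker inhibitor), compound 1 gives only a limit, > 4000 nM. Compound 2 likewise gives only a limit in this assay, > 4000 nM. Both values sit at the limit of > 4000 nM in this assay, at which 2 of the 2 values shown sit, so the step that the two limits leave unreadable from compound 1 to compound 2 has no readable size. Compound 2 thus stands at the limit of this assay, with no number of its own.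

Compound 3 `CCCCCC12CCC(c3nnc(-c4ccccc4C(F)(F)F)n3C)(CC1)CC2` differs from compound 2 by butyl in place of 4-(methylsulfonyl)phenoxy on a saturated chain carbon bound to a saturated ring carbon. Within the data shown here, the only measured step, a step that the two limits leave unreadable from compound 1 to compound 2, touches the same place but yields neither a size nor a direction, so nothing measured here bears on this change in a readable way. Compound 3 is therefore expected to stay at or near the limit in this assay, the step that the limit leaves unreadable from compound 2 to compound 3 expected to be within the scatter. The estimate for compound 3 is 6000 nM, expected to lie between 1500 nM and 25000 nM.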

Compound 3, half-maximal inhibitory concentration: 1300 nM
Estimate against measurement, compound 3: 4.6-fold (0.66 log units) above, outside the stated range (below it).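

At this position, on a saturated chain carbon bound to a saturated ring carbon, the arm can move the result off the limit of this assay, which neither earlier compound showed. Butyl in place of 4-(methylsulfonyl)phenoxy gives an at least 3.0-fold lower number from compound 2 to compound 3 (0.48 log units; beyond the scatter), and butyl in place of methanesulfonamido gives an at least 3.0-fold lower number from compound 1 to compound 3 (0.48 log units; beyond the scatter). Both steps have only a minimum size because their starting compounds give no number of their own: the limit of > 4000 nM in this assay, at which 2 of the 3 values shown sit.

Each step exchanges a whole arm, so the compounds shown do not separate the loss of the sulfonyl group from the loss of the other atoms of either arm. Going by these compounds, how far a longer chain such as hexyl, or a carboxylic acid in place of butyl, would move the value of compound 3 also remains open.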